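Amino Added to the Fluoropyridyl Ring: Expected Potency of Compound 4

A few compounds are considered here, and "the series" means these few. Any claim that something is new, unique, unknown or untested is made for them only; others in the source may bear on it.

Compound 1, `O=C(O)Cc1sc(C(c2ccc(F)cc2)c2ccc(F)cc2)nc1-c1ccnc(F)c1`, gives 4.7 nM.
Compound 2, `O=C(O)Cc1sc(C(c2ccc(F)cc2)c2ccc(F)cc2)nc1-c1ccccc1`, gives 240 nM.
Compound 3, `O=C(O)Cc1sc(C(c2ccc(F)cc2)c2ccc(F)cc2)nc1-c1ccnc(Cl)c1`, gives 39 nM.

All three share one core and differ only in the aromatic ring attached to it, measured in an in vitro functional assay on HEK285-7 cells for antagonist activity at prostaglandin D2 receptor 2 (Homo sapiens), read by BRET and beta-arrestin recruitment; a higher number here means a weaker inhibitor, a lower number a stronger inhibitor. Compound 3 stands second highest of the three numbers, between the other two: a 6.2-fold lower number from compound 2 to compound 3 (0.79 log units; beyond the scatter), and an 8.3-fold higher number from compound 1 to compound 3 (0.92 log units; beyond the scatter).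

Compound 4, `Nc1cc(-c2nc(C(c3ccc(F)cc3)c3ccc(F)cc3)sc2CC(=O)O)cc(F)n1`, has not been measured. Its change from compound 3 is 2-amino-6-fluoropyridin-4-yl in place of 2-chloropyridin-4-yl on an aromatic carbon. The step that bears most directly on it is an 8.3-fold higher number from compound 1 to compound 3 (0.92 log units; beyond the scatter), a modest step, since the change puts fluoro back where compound 3 carries chloro; a 51-fold higher number from compound 1 to compound 2 (1.71 log units; beyond the scatter), a large step, shows how much this ring matters. Among the compounds with values here, no measured step covers the added amino group, so its effect is unknown.

A lower number is therefore expected, roughly a 3.9-fold lower number from compound 3 to compound 4 (0.59 log units; beyond the scatter), moving toward compound 1 but with wide uncertainty. Compound 4 is estimated at 10 nM, with a likely range from 3 nM to 40 nM.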

Compound 4, half-maximal inhibitory concentration: 1400 nM
Beside the measured number, compound 4's estimate is 140-fold (2.15 log units) below it; measured number outside the range, above it.
By their numbers in this assay, from the lowest: compound 1; then compound 3; then compound 2; then compound 4.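

Putting an amino group in place of a hydrogen on the 2-fluoropyridin-4-yl ring has a very large effect (a 300-fold higher number from compound 1 to compound 4 (2.47 log units; beyond the scatter)), larger than swapping that whole ring for phenyl (a 51-fold higher number from compound 1 to compound 2 (1.71 log units; beyond the scatter)). The 2-amino-6-fluoropyridin-4-yl ring is also weaker than the 2-chloropyridin-4-yl ring (a 36-fold higher number from compound 3 to compound 4 (1.56 log units; beyond the scatter)) and even than plain phenyl (a 5.8-fold higher number from compound 2 to compound 4 (0.77 log units; beyond the scatter)), so keeping the ring nitrogen and a halogen does not by itself preserve potency. Nothing measured here gives a reason for this loss.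

Only the amino group is shown at this spot, so it remains open whether a methyl, hydroxyl or methoxy group in place of that hydrogen would cost as much. As far as these compounds go, how a 2-aminopyridin-4-yl ring, carrying the amino group without the fluoro, would compare is also open.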